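This account rests on a few compounds, and the source may have more. Where it says the series, first, only, none or still open, it means among the compounds named here.

Two compounds built on the shared core differ in one group on an aromatic carbon. Compound 1 `C[C@H](NC(=O)C(c1cccnc1)N(C(=O)c1ccco1)c1ccc([Si](C)(C)C)cc1)c1ccccc1` carries a trimethylsilyl group there, and in a toxicity assay on Vero C1008 cells (Chlorocebus sabaeus) for cytotoxicity, read by neutral red uptake, with a stated time of 5 days (on this read-out higher numbers stand for lower toxicity in this test and lower numbers for higher toxicity in this test), compound 1 gives 19400 nM. Compound 2 `C[C@H](NC(=O)C(c1cccnc1)N(C(=O)c1ccco1)c1ccc(-c2ccccc2)cc1)c1ccccc1` carries a six-membered aromatic ring of carbon only in its place. In this assay compound 2 gives > 200000 nM, which is a limit of the assay rather than a measured number. The step of an at least 10-fold higher number from compound 1 to compound 2 (1.01 log units; beyond the scatter) thus points toward lower toxicity for compound 2, although where compound 2 truly stands is open, since its value sits at the limit of > 200000 nM in this assay, at which 1 of the 2 values shown sits.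

Compound 3 `C[C@H](NC(=O)C(c1cccnc1)N(C(=O)c1cnco1)c1ccc(-c2ccccc2)cc1)c1ccccc1` keeps that ring and changes the other end of the molecule: 1,3-oxazol-5-yl in place of furan-2-yl on a carbonyl carbon. For the measured compounds named here, no measured step touches this part of the molecule, so the single measured step from compound 1 to compound 2 does not bear on it. With nothing pointing to a shift, compound 3 is expected to stay near compound 2 and most likely to be reported again only as a limit. The expected step of a number no higher from compound 2 to compound 3 (the limit leaves the size open) is therefore none beyond the scatter. Compound 3 is estimated at 200000 nM, within 50000 nM to 600000 nM.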

Compound 3, half-maximal cytotoxic concentration: 67100 nM
Estimate against measurement, compound 3: 3.0-fold (0.47 log units) above; the range from low to high includes it.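

In this assay, for the compounds shown here, the swap on the carbonyl carbon gives an at least 2.9-fold lower number from compound 2 to compound 3 (0.47 log units; beyond the scatter), so the end of the molecule that no earlier step touched does bear on the read-out, and the lower number stands for higher toxicity in this test. The change is small on paper: both rings are five-membered and aromatic, and the entering ring holds a nitrogen and 2 hydrogen-bond acceptors where the leaving ring holds 1 acceptor, so even this modest edit is enough to move the result beyond the scatter. The true size of the step stays open, because compound 2 stands at a limit and not at a measured number: the limit of > 200000 nM in this assay, at which 1 of the 3 values shown sits.

This single pair cannot tell whether the nitrogen itself or some other difference between the two rings drives the shift, or whether the same swap would act alike with the trimethylsilyl group of compound 1 in place of the six-membered aromatic ring. As far as these compounds go, how a quite different group on that carbonyl carbon, such as an amine or a short alkyl chain, would read in this assay also remains open.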